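Cyano for hydroxypyrrolidinylcarbonyl in a cinnamic acid series

The source may hold more compounds than are shown below. What is called first, only, known or untested is meant among the compounds shown, and "the series" means these compounds.

Compound 1 `COc1ccc(/C=C\C(=O)O)c(OCc2cn(-c3ccccc3C(=O)N3CCC(O)C3)nn2)c1CC=C(C)C`: 31500 nM
Compound 2 `COc1ccc(-n2cc(COc3c(/C=C\C(=O)O)ccc(OC)c3CC=C(C)C)nn2)cc1`: "not determined" (no result reported)

Compound 1 `COc1ccc(/C=C\C(=O)O)c(OCc2cn(-c3ccccc3C(=O)N3CCC(O)C3)nn2)c1CC=C(C)C` was tested in a functional assay on A-431 cells (Homo sapiens) for cytotoxicity, read by MTT assay, with a stated time of 24 h (on this read-out higher numbers stand for weaker inhibition and lower numbers for stronger inhibition), and gives 31500 nM. Compound 2 `COc1ccc(-n2cc(COc3c(/C=C\C(=O)O)ccc(OC)c3CC=C(C)C)nn2)cc1` was included in the same study, but in this assay compound 2 has only the entry "not determined" (no result reported), so no number is available for it. Among the measured compounds shown here, compound 1 therefore stands alone as the only compound with a number in this assay, and its value places it as a weak inhibitor in this read-out.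

Compound 3 `COc1ccc(/C=C\C(=O)O)c(OCc2cn(-c3ccccc3C#N)nn2)c1CC=C(C)C` differs from compound 1 in a single place: cyano in place of (3-hydroxypyrrolidin-1-yl)carbonyl on an aromatic carbon. For the measured compounds named here, no pair of measured compounds shows what this kind of exchange does in this assay, so there is no measured step to lean on. With only the value of compound 1 as a reference, the step is expected to stay within the scatter of repeated measurements, with no firm direction. The estimate for compound 3 is 25000 nM, with a range from 8000 nM to 80000 nM, which corresponds to an expected step of a 1.3-fold lower number from compound 1 to compound 3 (0.10 log units; within the scatter).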

Compound 3, half-maximal inhibitory concentration: 10300 nM
Estimate against measurement, compound 3: 2.4-fold (0.39 log units) above; the measured number falls inside the stated range.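

In this assay, among the compounds shown here, replacing (3-hydroxypyrrolidin-1-yl)carbonyl with cyano on an aromatic carbon gives a 3.1-fold lower number from compound 1 to compound 3 (0.49 log units; beyond the scatter), the first measured evidence that the read-out responds to a change at this place, on the six-membered aromatic ring of carbon only and ortho to a large group. The step also shows that the (3-hydroxypyrrolidin-1-yl)carbonyl group, with its 8 heavy atoms, its five-membered non-aromatic ring and its hydrogen-bond donor, is not required for the activity seen with compound 1, since cyano, with 2 heavy atoms and no ring, gives the lower number. No measurement bearing on why the number falls accompanies this result.

This single exchange alters the whole group at once, so it cannot separate the contribution of the hydroxyl from that of the pyrrolidine ring or the carbonyl. A pyrrolidin-1-ylcarbonyl group without the hydroxyl, a primary carboxamide, or a plain hydrogen at the same place would help to show which part of the change accounts for the step and whether cyano itself matters.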